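This account rests on a few compounds, and the source may have more. Where it says the series, first, only, none or still open, it means among the compounds named here.

Of the compounds shown here, two have so far been tested in a toxicity assay on A549 cells (Homo sapiens) for cytotoxicity, read by luminescence and CellTiter-Glo, with a stated time of 48 h; on this read-out higher numbers stand for lower toxicity in this test and lower numbers for higher toxicity in this test. Compound 1 `Nc1c(-c2ccc(Br)cc2)nc2ncccn12` gives a limit in this assay, > 100000 nM, so for it the test reports no number at all. Compound 2 `COCCCCOc1ccc(-c2nc3ncccn3c2NC2CCCCC2)cc1` gives the only number shown, 100000 nM, and this places it at the least toxic end of what this test reports; the single other value shown is described by the limit of > 100000 nM in this assay, at which 1 of the 2 values shown sits. Compound 3 `COc1ccc(-c2nc3ncccn3c2NC2CCCCC2)cc1` is the compound still to be measured, and it differs from compound 2 by hydrogen in place of 3-methoxypropyl on a saturated chain carbon bound to an oxygen on an aromatic ring. Going by the values given here, no measured pair differs in just one place, so there is no measured step to lean on. The step expected from compound 2 to compound 3 in this assay, no change at the digits printed from compound 2 to compound 3 (within the scatter), is therefore one that stays within the usual scatter, in no particular direction. Compound 3 is estimated at 100000 nM, with a range from 40000 nM to 100000 nM.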

Compound 3, half-maximal cytotoxic concentration: > 100000 nM
Compound 3 was reported as a limit; the forecaster's own chance of this, stated with the estimate: 55%; the middle value sits exactly at the limit.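

Shortening the 4-methoxybutoxy group to methoxy, with hydrogen in place of 3-methoxypropyl on a saturated chain carbon bound to an oxygen on an aromatic ring, gives a number no lower from compound 2 to compound 3 (the limit leaves the size open) in this assay. At this position, removing the long chain therefore brings no greater toxicity in this assay, so that chain is not required for the low toxicity of compound 2. How large the step is cannot be read, and the values now crowd at the end of the scale: the limit of > 100000 nM in this assay, at which 2 of the 3 values shown sit.

The compounds shown leave open whether a different group on this oxygen, such as a chain ending in an amine or a carboxylic acid, would give a clearly lower number. They also leave open whether any real gap separates compound 2 from compound 3.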